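The compounds below may be only part of what the source reports. "The series", "measured", "known", "first", "only" and "open" are said of these compounds alone.

Measured compounds:
compound 1 `COc1ccc(C(=O)Nc2cccc(/C=C/C(=O)c3nc4ccccc4[nH]3)c2)cc1` – 6330 nM
compound 2 `Cc1cccc(S(=O)(=O)Nc2cccc(/C=C/C(=O)c3nc4ccccc4[nH]3)c2)c1` – 791 nM

Going by the values given here, in a functional assay on 143B cells (Homo sapiens) for antiproliferative activity, read by MTT assay, with a stated time of 48 h (on this read-out lower numbers stand for stronger inhibition and higher numbers for weaker inhibition), compound 2 holds the lowest of the two numbers; its nearest neighbour is compound 1 at 6330 nM, set apart by the single measured step, an 8.0-fold lower number from compound 1 to compound 2 (0.90 log units; beyond the scatter). Compound 3 `Cc1ccc(S(=O)(=O)Nc2cccc(/C=C/C(=O)c3nc4ccccc4[nH]3)c2)cc1` is not yet measured. It differs from compound 2 by 4-methylphenyl in place of 3-methylphenyl on a sulfonyl sulfur. Among the compounds with values here, no measured step bears on this change: the only step known, an 8.0-fold lower number from compound 1 to compound 2 (0.90 log units; beyond the scatter), replaces (4-methoxyphenyl)carbonyl with (3-methylphenyl)sulfonyl and says nothing about the methyl's place on the phenyl ring. With nothing else to go on, no step beyond the scatter is expected in this assay in either direction. The estimated step is therefore a 1.0-fold higher number from compound 2 to compound 3 (0.00 log units; within the scatter), which stays within the scatter. Compound 3 is estimated at 800 nM, expected to fall between 300 nM and 2200 nM.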

Compound 3, half-maximal inhibitory concentration: 3220 nM
For compound 3 the middle estimate is 4.0-fold (0.60 log units) below the measured one, outside the stated range (above it).
By their numbers in this assay, from the lowest: compound 2; then compounds 3 and 1 (each within the scatter of the next).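

In this assay, the place of the methyl on the phenyl ring turns out to matter: with the same atoms joined differently, 4-methylphenyl in place of 3-methylphenyl on the sulfonyl sulfur gives a 4.1-fold higher number from compound 2 to compound 3 (0.61 log units; beyond the scatter). The sulfonyl link alone therefore does not carry the lower number of compound 2, since (4-methylphenyl)sulfonyl in place of (4-methoxyphenyl)carbonyl gives only a 2.0-fold lower number from compound 1 to compound 3 (0.29 log units; within the scatter). No measurement at hand accounts for the difference between the two methyl places.

Still open, going by these compounds, is how a plain phenyl, or an ethyl in place of the methyl, would stand against compound 2 and compound 3. Also open, on these data alone, is whether (3-methylphenyl)carbonyl on the nitrogen would keep the number of compound 2, which would separate the effect of the link from that of the ring.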